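Losing the Ring Chlorine and a Chain Carbon

The source may hold more compounds than are shown below. What is called first, only, known or untested is meant among the compounds shown, and "the series" means these compounds.

Three citrate-like acids sharing one core have been tested in an assay on isolated protein for inhibition of ATP-citrate synthase (Rattus norvegicus); a higher number here means a weaker inhibitor, a lower number a stronger inhibitor. Compound 1 `O=C(O)CC(O)(CSCCCCCCc1ccccc1Cl)C(=O)O` gives 69000 nM. Compound 2 `O=C(O)CC(O)(CSCCCCCCc1cccc(Cl)c1Cl)C(=O)O` gives 7300 nM, and compound 3 `O=C(O)CC(O)(CSCCCCCCc1ccc(Cl)c(Cl)c1)C(=O)O` gives 110000 nM. Compound 1 thus stands second highest of the three, close to compound 3 and far from compound 2: the step of a 1.6-fold higher number from compound 1 to compound 3 (0.20 log units; within the scatter) lies within the scatter, whereas a 9.5-fold lower number from compound 1 to compound 2 (0.98 log units; beyond the scatter) is a clear gain. The step of a 15-fold higher number from compound 2 to compound 3 (1.18 log units; beyond the scatter) shows how strongly the arrangement of the chlorines changes the outcome.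

Compound 4 `O=C(O)CC(O)(CSCCCCCc1ccccc1)C(=O)O` is the unmeasured one. It differs from compound 1 in this way: phenyl in place of 2-chlorobenzyl on a saturated chain carbon, five bonds along the chain from a sulfur. Among the compounds with values here, no measured step removes a chlorine or shortens the chain, so the evidence is indirect. Within the data shown here, the only step that bears on it is a 9.5-fold lower number from compound 1 to compound 2 (0.98 log units; beyond the scatter), where a chlorine was added and the number fell; taking one away points the other way, and the shorter chain is an open question. For compound 4 the expected step is a 2.2-fold higher number from compound 1 to compound 4 (0.34 log units; beyond the scatter), toward a weaker inhibitor. Compound 4 is estimated at 150000 nM, within a range from 40000 nM to 500000 nM.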

Compound 4, inhibition constant: 490000 nM
Compound 4: the middle estimate sits 3.3-fold (0.51 log units) below what was measured; low and high end bracket the measured number.
By their numbers in this assay, from the lowest: compound 2; then compounds 1 and 3 (each within the scatter of the next); then compound 4.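

The earlier compounds shown here only varied chlorines on one chain length, whereas compound 4 loses the ring chlorine and a chain carbon together, and this double change gives a 7.1-fold higher number from compound 1 to compound 4 (0.85 log units; beyond the scatter) in this assay. So replacing 2-chlorobenzyl with phenyl at this position takes the number clearly beyond the scatter toward a weaker inhibitor, which compound 3, sitting within the scatter of compound 1, did not show for its change of ring pattern. Nothing measured here explains why the number moves this way.

With both changes made in one step, the compounds shown cannot say how much of the rise belongs to the chlorine and how much to the chain carbon. A phenyl on the chain of compound 1 would separate the two, while a longer chain or a methoxy group on the ring remains an open question.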